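The source may hold more compounds than are shown below. What is called first, only, known or untested is meant among the compounds shown, and "the series" means these compounds.

Measured in a functional assay on EJ cells (Homo sapiens) for cytotoxicity, with a stated time of 48 h; on this read-out lower numbers stand for stronger inhibition of growth and higher numbers for weaker inhibition of growth
compound 1 `Nc1nc(-c2cc(N3C[C@H](O)[C@@H](O)C3)ccc2O)cc(C2CCCCC2)n1` gives 1200 nM
compound 2 `Nc1nc(-c2cc(N3C[C@H](O)[C@@H](O)C3)ccc2O)cc(C2CCCNC2)n1` gives > 10000 nM as a limit

Compound 2 gives only a limit, not a number (the limit of > 10000 nM in this assay, at which 1 of the 2 values shown sits). Compound 3 `Nc1nc(-c2cc(N3C[C@H](O)[C@@H](O)C3)ccc2O)cc(C2CCCC2)n1` carries cyclopentyl in place of piperidin-3-yl on an aromatic carbon. Going by the values given here, the one measured step bearing on this is piperidin-3-yl replacing cyclohexyl (an at least 8.3-fold higher number from compound 1 to compound 2 (0.92 log units; beyond the scatter)), which lies beyond the scatter. With a ring of carbon only restored, a lower number is expected in this assay, the estimate being an at least 5.0-fold lower number from compound 2 to compound 3 (0.69 log units; beyond the scatter) on this reading. For compound 3 the expected value is 2000 nM, with an estimated range from 700 nM to 6000 nM as the likely span.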

Compound 3, concentration for 50% growth inhibition: 900 nM
For compound 3 the middle estimate is 2.2-fold (0.35 log units) above the measured one, within the range that was stated.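

In this assay, the change from six-membered cyclohexyl to five-membered cyclopentyl stays within the scatter: a 1.3-fold lower number from compound 1 to compound 3 (0.12 log units; within the scatter). Among these three rings, only piperidin-3-yl stands apart, and the step of an at least 11-fold lower number from compound 2 to compound 3 (1.04 log units; beyond the scatter) gives only a lower bound on that gap. Compound 2 carries a limit, not a number: the limit of > 10000 nM in this assay, at which 1 of the 3 values shown sits.

From the compounds shown here alone, whether tetrahydropyranyl, with a ring oxygen in place of the ring nitrogen, would stay with the carbon rings or with piperidin-3-yl remains open. So does the behaviour of an open chain such as isopropyl at this position.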